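Compound 3: An Unsaturated Chain on a Stable Parent

The compounds below may be only part of what the source reports. "The series", "measured", "known", "first", "only" and "open" are said of these compounds alone.

Going by the values given here, in an ADME assay on microsomes from liver (Mus musculus) for metabolic stability, using NADPH, with a stated time of 10 min (on this read-out lower numbers stand for a less stable compound and higher numbers for a more stable compound), compound 1 `NCCCCN(C[C@H]1Cc2ncccc2CN1)[C@H]1CCCc2cccnc21` gives 86% and holds the higher of the two numbers so far. Compound 2 `NCCCCN(C[C@@H]1Cc2ncccc2CN1)[C@H]1CCCc2cccnc21` gives 75% on the same read-out. Among the compounds with values here, the only measured step of a number 11 percentage points lower from compound 1 to compound 2 (beyond the scatter) goes with the fact that compounds 1 and 2 differ only in the configuration as drawn and not with any change in the chain, so it offers only a yardstick of size.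

Compound 3 `NC/C=C\CN(C[C@H]1Cc2ncccc2CN1)[C@H]1CCCc2cccnc21` keeps the core of compound 1 and alters the chain: 3-aminoprop-1-en-1-yl in place of 3-aminopropyl on a saturated chain carbon bound to an amine nitrogen. Within the data shown here, no measurement yet covers such a chain change, so a slightly lower number is expected, most likely with no step beyond the scatter. The expected step is a number 6 percentage points lower from compound 1 to compound 3 (within the scatter) and remains uncertain. For compound 3 an estimated 80% is expected, with a range from 62% to 93% on this read-out.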

Compound 3, percent of the compound remaining: 37%
Compound 3: middle estimate off by 43 percentage points, on the high side, and the stated range ends above it.
By their numbers in this assay, from the lowest: compound 3; then compound 2; then compound 1.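

In this assay, the chain on the core of compound 1 proves to be a sensitive place: 3-aminoprop-1-en-1-yl in place of 3-aminopropyl gives a number 49 percentage points lower from compound 1 to compound 3 (beyond the scatter) on a saturated chain carbon bound to an amine nitrogen. The two groups count the same heavy atoms, hydrogen-bond donors and acceptors, and the entering group differs by its double bond outside aromatic rings, yet this step is larger than the only earlier one, a number 11 percentage points lower from compound 1 to compound 2 (beyond the scatter), which came with configuration alone. Nothing measured here bears on why the number falls.

Open, as far as these compounds go, is whether the step belongs to the double bond as drawn, or would also appear with a triple bond or a longer chain. Also open, from the compounds shown here alone, is whether the core of compound 2 would respond in the same way to 4-aminobut-2-en-1-yl, and what a hydroxyl group at the chain end would do.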